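Methoxypyridinyl for chloromethoxyphenyl on the carbonyl carbon

A few compounds are considered here, and "the series" means these few. Any claim that something is new, unique, unknown or untested is made for them only; others in the source may bear on it.

Measured compounds in a functional assay on the whole organism (blood) with Rattus norvegicus as the target, with stated times of 24 h and 1 h, at a dose of 5 mg/kg by the intraperitoneal route; on this read-out higher numbers stand for a stronger effect at the one dose given and lower numbers for a weaker effect:
compound 1 `COc1ccc(Cl)cc1C(=O)NCCC1CCN(S(=O)(=O)NC(=O)NC[C@@H]2C[C@@H]3CC[C@@H]2O3)CC1`, 30%
compound 2 `COc1ccc(Cl)cc1C(=O)NCCC1CCN(S(=O)(=O)NC(=O)NC[C@H]2C[C@@H]3CC[C@@H]2O3)CC1`, 27%
compound 3 `COc1ccc(Cl)cc1C(=O)NCCC1CCN(S(=O)(=O)NC(=O)NN2CCCCCC2)CC1`, 36%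

Compound 2 stands at 27% in this assay. Its nearest neighbour is compound 1, and the step of a number 3 percentage points lower from compound 1 to compound 2 (within the scatter) is within the scatter; the compounds differ only in configuration as drawn (the fact that compounds 1 and 2 differ only in the configuration as drawn). Toward compound 3 the step of a number 9 percentage points higher from compound 2 to compound 3 (within the scatter) is also within the scatter, as is a number 6 percentage points higher from compound 1 to compound 3 (within the scatter). The three numbers therefore cannot be told apart.

Compound 4 `COc1ncccc1C(=O)NCCC1CCN(S(=O)(=O)NC(=O)NC[C@H]2C[C@@H]3CC[C@@H]2O3)CC1` differs from compound 2 by 2-methoxypyridin-3-yl in place of 5-chloro-2-methoxyphenyl on a carbonyl carbon. Among the measured compounds shown here, none of the measured steps touches this part of the shared core: the steps measured so far concern configuration and the group on the amide-type nitrogen of the sulfonylurea end. No step therefore bears directly on the change to compound 4, and no direction is indicated by the numbers shown.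

For compound 4 the expectation is thus a number near that of compound 2, with the step of no change at the digits printed from compound 2 to compound 4 (within the scatter) expected to stay within the scatter. The estimate for compound 4 in this assay is 27%, with a range of 10% to 45%.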

Compound 4, a percentage reported as activity, at one dose (the size of the read-out at that dose, not a potency): 14%
Estimate against measurement, compound 4: 13 percentage points above, within the range that was stated.
By their numbers in this assay, from the lowest: compound 4; then compounds 2, 1 and 3 (each within the scatter of the next).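

In this assay, among the compounds shown here, the group on the carbonyl carbon is the first place where a single change gives a step beyond the scatter: 2-methoxypyridin-3-yl in place of 5-chloro-2-methoxyphenyl gives a number 13 percentage points lower from compound 2 to compound 4 (beyond the scatter). The steps in configuration and on the amide-type nitrogen all stayed within the scatter, so among the places varied so far, only this one has shown a readable, though modest, effect. Nothing at hand gives a cause for this step.

The change removes the chlorine and brings in a ring nitrogen together, so a phenyl ring carrying methoxy alone would be needed to separate the two. From the compounds shown here alone, whether the step carries over to compound 1 or compound 3, with their different ends, remains open.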